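The source may hold more compounds than are shown below. What is called first, only, known or untested is meant among the compounds shown, and "the series" means these compounds.

In a functional assay on HepG2 cells (Homo sapiens) for cytotoxicity, with a stated time of 72 h (a higher number here means that more compound is needed for the effect, a lower number that less compound is needed), compound 1 `COc1ccc(/C=C/[C@@](C)(/C=C/c2ccc(O)c(C=O)c2)CCC=C(C)C)cc1` gives > 26000 nM as a limit of the assay and not as a number. Compound 2 `CCOC(=O)/C=C/c1cc(/C=C/[C@](C)(/C=C/c2ccc(OC)cc2)CCC=C(C)C)ccc1O` gives > 52000 nM as a limit too. Among the measured compounds shown here, compound 2 therefore has no exact place on the scale, and the one other value available is also only a limit.

For the measured compounds named here, the only measured step that bears on the next change is a step that the two limits leave unreadable from compound 1 to compound 2 with 2-(ethoxycarbonyl)ethenyl in place of formyl on an aromatic carbon. That step offers no size to carry forward.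

Compound 3 `CCOC(=O)/C(C)=C/c1cc(/C=C/[C@](C)(/C=C/c2ccc(OC)cc2)CCC=C(C)C)ccc1O` alters the same group, with 2-(ethoxycarbonyl)prop-1-en-1-yl in place of 2-(ethoxycarbonyl)ethenyl on an aromatic carbon ortho to a hydroxy group. The counted difference is 2-(ethoxycarbonyl)prop-1-en-1-yl in place of 2-(ethoxycarbonyl)ethenyl on an aromatic carbon and the rest of the structure stays as it is in compound 2.

With no readable step as a guide, no change beyond the scatter is expected in this assay and no direction can be argued. The expected step is a step that the limit leaves unreadable from compound 2 to compound 3 as a rough estimate. For compound 3 the estimated value is 60000 nM with an expected range from 25000 nM to 150000 nM in this estimate.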

Compound 3, half-maximal effective concentration: > 52000 nM
Compound 3 was reported as a limit (the forecaster's own chance of this, stated with the estimate: 80%); the middle value lies beyond the limit too.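

In this assay, among the compounds shown here, compound 1, compound 2 and compound 3 are all reported only as limits of the assay and not as numbers, and no step among them can be read. Going by these compounds, what stays open is the concentration at which each compound reaches its half-maximal effect, and whether exchanging formyl, 2-(ethoxycarbonyl)ethenyl and 2-(ethoxycarbonyl)prop-1-en-1-yl changes it at all.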